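This account rests on a few compounds, and the source may have more. Where it says the series, first, only, none or still open, it means among the compounds named here.

Of the compounds shown here, three of a shared core have been measured so far in an assay for inhibition of histone-lysine N-methyltransferase, H3 lysine-79 specific (Homo sapiens), read by scintillation counting, with stated times of 15 min and 60 min, tested at 50 uM, in the presence of a further agent that is not named here; a higher number here means a stronger effect of the compound at the concentration tested, a lower number a weaker effect. Compound 1 `COc1ccccc1-c1nnc2sc(/C=C/c3ccco3)nn12` gives 75% in this assay. Compound 2 `Fc1ccc(-c2nnc3sc(/C=C/c4ccco4)nn23)cc1` gives 44% in this assay. Compound 3 `Cc1occc1-c1nnc2sc(Cc3ccccc3)nn12` gives 13% in this assay. On these three numbers compound 2 stands second highest: compound 1 sits above it by a gap that lies beyond the usual scatter of this assay, and compound 3 sits below it by a gap of the same size, also beyond the scatter.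

The next compound, compound 4 `C(=C/c1nn2c(C3CCCCC3)nnc2s1)\c1ccco1`, is not yet measured. It differs from compound 2 in one place: cyclohexyl in place of 4-fluorophenyl on an aromatic carbon. Going by the values given here, no two measured compounds of this set differ in a single place, so no measured step can guide the size of this change. Without such a guide, the step is expected to be small, most likely downward or none beyond the scatter, as the shared core carries the furan vinyl group in both compounds. The step from compound 2 to compound 4 is estimated as a number 9 percentage points lower from compound 2 to compound 4 (within the scatter). Compound 4 is therefore expected to give about 35% in this assay, within a range from 10% to 65%.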

Compound 4, a percentage reported as inhibition, at one concentration (the size of the read-out at that concentration, not a potency): 68%
Compound 4: the middle estimate sits 33 percentage points below what was measured; the whole stated range lies below it.
By their numbers in this assay, from the lowest: compound 3; then compound 2; then compounds 4 and 1 (each within the scatter of the next).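

In this assay, going by these compounds alone, the change from 4-fluorophenyl to cyclohexyl, on an aromatic carbon of the five-membered ring between two ring nitrogen atoms, gives a number 24 percentage points higher from compound 2 to compound 4 (beyond the scatter) and is the first single-place step in this set. It shows that the read-out responds to what sits at this position, and that an aromatic ring is not required there, since a non-aromatic ring of carbon only serves at least as well in this pair. Nothing measured here explains why the step runs in this direction.

From the compounds shown here alone, whether a smaller carbon ring such as cyclopentyl, an open chain such as butyl, or a cyclohexyl ring carrying an amine would hold this level remains open. A single pair also cannot say whether the same swap would act alike on a core without the furan vinyl group.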